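Fluoro to trifluoromethyl on the 4-fluorophenyl ring

This account rests on a few compounds, and the source may have more. Where it says the series, first, only, none or still open, it means among the compounds named here.

Measured so far:
compound 1 `COc1cccc(/C=C/C(=O)Nc2cc(C(=O)c3cc(OC)c(OC)c(OC)c3)ccc2OC)c1`: 3100 nM
compound 2 `COc1ccc(C(=O)c2cc(OC)c(OC)c(OC)c2)cc1NC(=O)/C=C/c1ccc(F)cc1`: 400 nM

Among the compounds with values here, in a functional assay on B16 cells (Mus musculus) for cytotoxicity, read by MTT assay, with a stated time of 72 h (on this read-out lower numbers stand for stronger inhibition and higher numbers for weaker inhibition), compound 2 holds the lowest of the two numbers; the only measured step, a 7.8-fold lower number from compound 1 to compound 2 (0.89 log units; beyond the scatter), changed the aryl on the ethenyl chain. Compound 3 `COc1ccc(C(=O)c2cc(OC)c(OC)c(OC)c2)cc1NC(=O)/C=C/c1ccc(C(F)(F)F)cc1` carries trifluoromethyl in place of fluoro on an aromatic carbon. Within the data shown here, no measured step changes this group, so the single step gives only a rough sense of how much this ring position matters. A change of modest size or none beyond the scatter is expected in this assay. Compound 3 is estimated at 600 nM (range 200 nM to 2000 nM), which is expected to mean a 1.5-fold higher number from compound 2 to compound 3 (0.18 log units; within the scatter).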

Compound 3, half-maximal inhibitory concentration: 100 nM
Compound 3: the middle estimate sits 6.0-fold (0.78 log units) above what was measured; measured number below the stated range.
By their numbers in this assay, from the lowest: compound 3; then compound 2; then compound 1.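

In this assay, the ring position on the ethenyl chain still has room after the gain seen with compound 2: trifluoromethyl in place of fluoro gives a 4.0-fold lower number from compound 2 to compound 3 (0.60 log units; beyond the scatter) and is beyond the scatter. Relative to the 3-methoxyphenyl, the 4-(trifluoromethyl)phenyl gives a 31-fold lower number from compound 1 to compound 3 (1.49 log units; beyond the scatter) as the largest step in this set, making compound 3 the most potent of the three. No supporting data explain this gain.

The compounds shown leave open whether the trend is specific to trifluoromethyl or would extend to a chlorine, a nitrile or an amine in the same place.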